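The source may report more compounds than this note shows. Statements on the series, on what has been measured and on what is new or still open speak of the compounds shown alone.

In a functional assay on PC-3 cells (Homo sapiens) for antiproliferative activity, read by WST assay, with a stated time of 3 days (on this read-out higher numbers stand for weaker inhibition and lower numbers for stronger inhibition), compound 1 (`CCN(CC)CCCCOc1c(-c2cc(OC)c(OC)c(OC)c2)oc2ccccc2c1=O`) gives 13700 nM, and compound 2 (`CCCN(CCC)CCCCCOc1c(-c2cc(OC)c(OC)c(OC)c2)oc2ccccc2c1=O`) gives 2600 nM, the lower of the two numbers and so the stronger inhibition. Compound 3 (`CCCCCN(CCCCC)CCCCCOc1c(-c2cc(OC)c(OC)c(OC)c2)oc2ccccc2c1=O`) has not yet been measured. It keeps the core of compound 2 and alters one group: dipentylamino in place of dipropylamino on a saturated chain carbon, five bonds along the chain from an oxygen on an aromatic ring. In words, this is dipentylamino in place of dipropylamino on a saturated chain carbon, five bonds along the chain from an oxygen on an aromatic ring. Among the compounds with values here, only one measured step bears on this change: a 5.3-fold lower number from compound 1 to compound 2 (0.72 log units; beyond the scatter), a modest step beyond the scatter, with (dipropylamino)methyl in place of diethylamino. A single step sets no trend, so only a smaller move in the same direction is expected in this assay. The expected step is a 1.5-fold lower number from compound 2 to compound 3 (0.18 log units; within the scatter), which may not clear the scatter. For compound 3 the estimated value is 1700 nM, with an expected range from 550 nM to 5500 nM.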

Compound 3, half-maximal inhibitory concentration: 9600 nM
Compound 3: middle estimate off by 5.6-fold (0.75 log units), on the low side; measured number outside the range, above it.
By their numbers in this assay, from the lowest: compound 2; then compounds 3 and 1 (each within the scatter of the next).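

In this assay, swapping dipropylamino for dipentylamino does not continue the earlier gain but turns it around, with a 3.7-fold higher number from compound 2 to compound 3 (0.57 log units; beyond the scatter) beyond the scatter. Lengthening the groups on the nitrogen therefore does not keep lowering the number, and compound 3 goes against any such trend. The comparison with the first compound, a 1.4-fold lower number from compound 1 to compound 3 (0.15 log units; within the scatter) within the scatter, shows that compound 3 keeps none of the gain seen at compound 2, and nothing measured here explains the rise.

Dibutylamino remains open, and it would show whether the number climbs gradually or abruptly beyond dipropylamino. Ring amines such as piperidine or morpholine in the same place also remain open, as does dipropylamino on the shorter chain of compound 1, which would separate the effect of the chain from that of the amine.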